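The source may hold more compounds than are shown below. What is called first, only, known or untested is meant among the compounds shown, and "the series" means these compounds.

Measured so far in a functional assay on LM7 cells (Homo sapiens) for antiproliferative activity, read by MTT assay, with a stated time of 72 h; on this read-out higher numbers stand for weaker inhibition and lower numbers for stronger inhibition:
- compound 1 `Cc1ccc2c(=O)c(CSC(=S)N(C(C)C)C(C)C)coc2c1`: 6300 nM
- compound 2 `CCN(CC)C(=S)SCc1cc(=O)c2ccc(Cl)cc2o1`: 8800 nM
- compound 3 `CCOC(=O)c1cc(=O)c2cc(CSC(=S)N(C(C)C)C(C)C)ccc2o1`: reported only as a limit of the assay, > 25000 nM

Compound 1 gives the lowest of the two numbers in this assay; compound 2 sits a short way from it, and the gap between compound 1 and compound 2 lies within the scatter, so no order can be read from those two. Compound 3 is known only as a limit, (the limit of > 25000 nM in this assay, at which 1 of the 3 values shown sits), and contributes no number.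

The step to compound 4 `CC(C)N(C(=S)SCc1coc2cc(Cl)ccc2c1=O)C(C)C` changes compound 1 in one place: chloro in place of methyl on an aromatic carbon. For the measured compounds named here, no measured pair isolates this change, so its size cannot be read off directly. Going by the values given here, the only bearing comes from compound 2, which also carries a chloro on its core and gives 8800 nM, a value within the scatter of compound 1 at 6300 nM. On that basis no step beyond the scatter is expected in this assay, in either direction.

For compound 4 the estimate in this assay is 7000 nM, with a range from 3000 nM to 18000 nM. The step this implies, a 1.1-fold higher number from compound 1 to compound 4 (0.05 log units; within the scatter), is expected to stay within the scatter.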

Compound 4, half-maximal inhibitory concentration: > 25000 nM
Compound 4 gave a limit, no number (the forecaster's own chance of this, stated with the estimate: 12%); middle value at least 3.5-fold (0.55 log units) from the limit.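

In this assay, for the compounds shown here, chloro in place of methyl on an aromatic carbon, meta to a fused ring and para to a fused ring, is the first single change that can be read, and it comes out as an at least 3.9-fold higher number from compound 1 to compound 4 (0.59 log units; beyond the scatter). Going by these compounds alone, compound 4 is reported only as a limit of the assay, so this step gives a lower bound and its full size stays unknown: the limit of > 25000 nM in this assay, at which 2 of the 4 values shown sit. On the core and side chain of compound 1, this position therefore does not accept chloro as an equal of methyl in this read-out, a sensitivity that no earlier compound could isolate.

The compounds shown leave open whether the change in the step follows from the arrival of chloro or from the departure of methyl, and hydrogen, fluoro, methoxy or ethyl at this position would separate the two. Also open, as far as these compounds go, is whether the same exchange gives a step of similar size when the side chain of compound 1 ends in a pyrrolidine or morpholine amine.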